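Two Aryl Amides on a Shared Core, and a Third

This account rests on a few compounds, and the source may have more. Where it says the series, first, only, none or still open, it means among the compounds named here.

Compound 1 `O=C(Nc1cccc(-c2oc3cc(-c4ccc(F)cc4)ccc3c(=O)c2O)c1)c1cccc(F)c1` gives 15800 nM in a functional assay on GTL 16 cells for antiproliferative activity against GTL 16 cell line (Homo sapiens), read by CCK-8 assay, with a stated time of 72 h; a higher number here means a weaker inhibitor, a lower number a stronger inhibitor. Compound 2 `COc1ccc(C(=O)Nc2cccc(-c3oc4cc(-c5ccc(F)cc5)ccc4c(=O)c3O)c2)c(F)c1` gives 15300 nM in this assay; of the two numbers shown, compound 2 holds the lower one, yet a 1.0-fold lower number from compound 1 to compound 2 (0.01 log units; within the scatter), so the pair cannot be told apart. Compound 3 `COc1cc(OC)cc(C(=O)Nc2cccc(-c3oc4cc(-c5ccc(F)cc5)ccc4c(=O)c3O)c2)c1` carries 3,5-dimethoxyphenyl in place of 2-fluoro-4-methoxyphenyl on a carbonyl carbon. Among the compounds with values here, the only step that bears on this change is a 1.0-fold lower number from compound 1 to compound 2 (0.01 log units; within the scatter), an earlier exchange of the aryl group on the same carbonyl carbon that left the number where it was. Compound 3 is therefore expected to show no step beyond the scatter, a 1.0-fold lower number from compound 2 to compound 3 (0.01 log units; within the scatter). Compound 3 is estimated at 15000 nM, between 6000 nM and 40000 nM.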

Compound 3, half-maximal inhibitory concentration: 19600 nM
Beside the measured number, compound 3's estimate is 1.3-fold (0.12 log units) below it; measured number inside the range.
By their numbers in this assay, from the lowest: compounds 2, 1 and 3 (each within the scatter of the next).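

In this assay, putting 3,5-dimethoxyphenyl on the carbonyl carbon in place of 2-fluoro-4-methoxyphenyl gives a 1.3-fold higher number from compound 2 to compound 3 (0.11 log units; within the scatter), and putting it in place of 3-fluorophenyl gives a 1.2-fold higher number from compound 1 to compound 3 (0.09 log units; within the scatter). This position has now carried a third aryl group, this one without fluorine, and all three numbers remain within the scatter of each other. Nothing available explains this insensitivity. Still open, on these data alone, is whether a non-aryl group on this carbonyl carbon, such as an amine, a carboxylic acid or a longer alkyl chain, would move the number beyond the scatter.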